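Sulfonyl aryl swap on two amide cores

The compounds below may be only part of what the source reports. "The series", "measured", "known", "first", "only" and "open" are said of these compounds alone.

Three members of the series have numbers in an assay on MDA-MB-231 cells for displacement of a labelled ligand from C-X-C chemokine receptor type 4 (Homo sapiens), read by fluorescence and microscopy, with stated times of 10 min and 30 min; on this read-out higher numbers stand for an effect only at larger amounts of compound and lower numbers for an effect already at smaller amounts. Compound 1 `O=C(NCc1ccc(CNS(=O)(=O)c2cccc(F)c2)cc1)c1cccnc1` and compound 2 `O=C(NCc1ccc(CNS(=O)(=O)c2ccc([N+](=O)[O-])cc2)cc1)c1cccnc1` share one amide core and differ only at the sulfonyl sulfur; compound 3 `Cc1ccccc1C(=O)NCc1ccc(CNS(=O)(=O)c2ccc([N+](=O)[O-])cc2)cc1` carries the aryl sulfonyl group of compound 2 on a second amide core. In this assay compound 2 gives 100 nM, compound 1 gives 1000 nM and compound 3 gives 100 nM.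

Two steps are counted. The first, (3-fluorophenyl in place of 4-nitrophenyl on a sulfonyl sulfur), gives a 10-fold higher number from compound 2 to compound 1 (1.00 log units; beyond the scatter). The second, (2-methylphenyl in place of pyridin-3-yl on a carbonyl carbon), gives no change at the digits printed from compound 2 to compound 3 (within the scatter); this is also how the two cores differ.

Compound 4 `Cc1ccccc1C(=O)NCc1ccc(CNS(=O)(=O)c2cccc(F)c2)cc1` is not yet measured. It differs from compound 3 by 3-fluorophenyl in place of 4-nitrophenyl on a sulfonyl sulfur, the same change that takes compound 2 to compound 1, and the place line reads the same word for word in both cases, so this is the same change made on the second core. Going by the values given here, the only prior example of it is the step from compound 2 to compound 1, and the cores themselves sit level in this assay, so the step is expected to repeat at roughly the same size: for compound 4 the expected step is a 10-fold higher number from compound 3 to compound 4 (1.00 log units; beyond the scatter), set beside a 10-fold higher number from compound 2 to compound 1 (1.00 log units; beyond the scatter). The estimate for compound 4 in this assay is therefore 1000 nM, expected to fall between 300 nM and 3000 nM. This rests on a single paired step and on the level reading of compound 2 and compound 3, so the expectation is held loosely.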

Compound 4, effective concentration (reported as EC, without a stated level of effect): 100 nM
Compound 4: the middle estimate sits 10-fold (1.00 log units) above what was measured; measured number below the stated range.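

In this assay, going by these compounds alone, 3-fluorophenyl in place of 4-nitrophenyl on a sulfonyl sulfur does not carry over unchanged from the first core to the second, where the result is no change at the digits printed from compound 3 to compound 4 (within the scatter): the same change on two cores in this assay, a 10-fold higher number (1.00 log units; beyond the scatter) from compound 2 to compound 1 and no change at the digits printed (within the scatter) from compound 3 to compound 4, 10-fold (1.00 log units) apart, beyond the scatter of two such steps Read along the other edge of the same four compounds, 2-methylphenyl in place of pyridin-3-yl on a carbonyl carbon gives a 10-fold lower number from compound 1 to compound 4 (1.00 log units; beyond the scatter), so that change also reads differently according to the group on the sulfonyl sulfur: the same change on two cores in this assay, no change at the digits printed (within the scatter) from compound 2 to compound 3 and a 10-fold lower number (1.00 log units; beyond the scatter) from compound 1 to compound 4, 10-fold (1.00 log units) apart, beyond the scatter of two such steps Both gaps hang on the single value of compound 1, 1000 nM, so the set shows that the sulfonyl change cannot be assumed to transfer between these two cores, but not what lies behind the difference or how the change would run on any other core.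

Within the data shown here, only two groups appear on the sulfonyl sulfur and two on the carbonyl carbon, so it remains open whether the higher number of compound 1 is an isolated case or part of a wider trend on the core it shares with compound 2. Going by these compounds, it is also open whether a sulfonyl aryl group carrying a nitrile or a carboxylic acid, or an aliphatic amine on the carbonyl carbon, would follow compound 1 or compound 4.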